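The source may hold more compounds than are shown below. What is called first, only, known or untested is meant among the compounds shown, and "the series" means these compounds.

Working notes on the series. Within the data shown here, of the three compounds measured so far, compound 3 `COc1ccc(-n2nc(Sc3ccc(Cl)cc3)cc(CC[C@@H](C)NC(=O)[C@H]3CCNC[C@@H]3c3ccc(Cl)cc3)c2=O)cc1` stands lowest in a functional assay with Melanocortin receptor 4 (Homo sapiens) as the target, read by cAMP accumulation; on this read-out lower numbers stand for an effect already at smaller amounts and higher numbers for an effect only at larger amounts of compound: compound 3 gives 150 nM. Among the measured compounds shown here, compound 1 `COc1ccc(-n2nc(Sc3ccc(Cl)cc3)cc(CC[C@@H](C)NC(=O)[C@H]3CNCC[C@@H]3c3cccc(Cl)c3)c2=O)cc1` gives 680 nM, and compound 2 `COc1ccc(-n2nc(Sc3ccc(Cl)cc3)cc(CC[C@@H](C)NC(=O)[C@H]3CNCC[C@@H]3c3ccccc3F)c2=O)cc1` gives 550 nM; the one step among them, a 1.2-fold lower number from compound 1 to compound 2 (0.09 log units; within the scatter), concerns the group on the saturated ring carbon and stays within the scatter. Compound 4 `COc1ccc(-n2nc(Sc3ccc(Cl)cc3)cc(CC[C@@H](C)NC(=O)[C@H]3CCNC[C@@H]3c3ccc(C#N)cc3)c2=O)cc1` differs from compound 3 by cyano in place of chloro on an aromatic carbon. For the measured compounds named here, no measured step touches the group on the aromatic ring, so nothing in the data speaks for a shift in either direction. The expected step is therefore small, a 1.7-fold higher number from compound 3 to compound 4 (0.22 log units; within the scatter), with no change beyond the scatter. Compound 4 is estimated at 250 nM, within a range from 100 nM to 650 nM.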

Compound 4, half-maximal effective concentration: 120 nM
Compound 4: the middle estimate sits 2.1-fold (0.32 log units) above what was measured, within the range that was stated.
By their numbers in this assay, from the lowest: compounds 4 and 3 (each within the scatter of the next); then compounds 2 and 1 (each within the scatter of the next).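

In this assay, 4-chlorophenyl to 4-cyanophenyl gives a 1.3-fold lower number from compound 3 to compound 4 (0.10 log units; within the scatter), so this aromatic carbon accepts cyano in place of chloro with no change beyond the scatter. Among these compounds, this is the first measured step at this position; the only earlier step concerned the group on a saturated ring carbon. No available evidence bears on why the two groups read alike. The compounds shown leave open whether an amine or a carboxylic acid on this aromatic carbon would also stay within the scatter. Going by these compounds, whether cyano in place of chloro reads the same on the core of compound 1 also remains open.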